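The source may report more compounds than this note shows. Statements on the series, on what has been measured and on what is new or still open speak of the compounds shown alone.

Compound 1, `CCNC(=O)N1CCN(C(=S)SCc2cn(Cc3ccc(Cl)cc3)nn2)CC1`, in a functional assay on MGC-803 cells (Homo sapiens) for cytotoxicity, read by MTT assay, with a stated time of 72 h (a lower number here means a stronger inhibitor, a higher number a weaker inhibitor), gives 35400 nM. Compound 2, `CCNC(=O)N1CCN(C(=S)SCc2cn(Cc3ccc(C)cc3)nn2)CC1`, gives 19800 nM. Compound 3, `COc1ccc(Cn2cc(CSC(=S)N3CCN(C(N)=O)CC3)nn2)cc1`, gives only a limit of the assay, > 128000 nM.

Within the data shown here, compound 3 therefore stands at the limit rather than at a number, and is the one of the three values that sits there (the limit of > 128000 nM in this assay, at which 1 of the 3 values shown sits). The step to compound 4, `CCNC(=O)N1CCN(C(=S)SCc2cn(Cc3ccc(OC)cc3)nn2)CC1`, is ethyl in place of hydrogen on an amide-type nitrogen. Among the measured compounds shown here, no measured step touches that amide nitrogen. For the measured compounds named here, the only measured step, a 1.8-fold lower number from compound 1 to compound 2 (0.25 log units; within the scatter), concerns the group on the aromatic carbon and lies within the scatter. What the measured compounds do show is that the two with the ethylcarbamoyl group, compound 1 and compound 2, give numbers, whereas compound 3 with the plain carbamoyl gives a limit. The direction from compound 3 to compound 4 is thus expected to be toward a number, with an at least 3.2-fold lower number from compound 3 to compound 4 (0.50 log units; beyond the scatter) estimated, though a second limit cannot be excluded. Compound 4 is expected to give about 40000 nM, between 15000 nM and 128000 nM.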

Compound 4, half-maximal inhibitory concentration: > 128000 nM
Compound 4 gave a limit, no number (the forecaster's own chance of this, stated with the estimate: 30%); middle value at least 3.2-fold (0.50 log units) away from the limit.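

With the ethylcarbamoyl group held fixed, the group on the aromatic carbon turns out to matter in this assay, which the earlier step within the scatter had not shown. Methoxy in place of methyl brings an at least 6.4-fold higher number from compound 2 to compound 4 (0.81 log units; beyond the scatter), and methoxy in place of chloro brings an at least 3.6-fold higher number from compound 1 to compound 4 (0.55 log units; beyond the scatter). Compound 3 and compound 4 both stand at a limit rather than at a number, so the step between them cannot be read, and the ethylcarbamoyl group alone does not secure a number: the limit of > 128000 nM in this assay, at which 2 of the 4 values shown sit.

The compounds shown leave open what ethyl in place of hydrogen on the amide-type nitrogen does when the aromatic carbon carries chloro or methyl. They also leave open whether a longer chain on that nitrogen, or a hydroxyl group in place of methoxy on the aromatic carbon, would give a number.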